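Fluoro for Ethyl on the Aryl Urea

This account rests on a few compounds, and the source may have more. Where it says the series, first, only, none or still open, it means among the compounds named here.

Measured so far:
compound 1, `CCc1ccc(NC(=O)N[C@H](C)c2ccccc2)cc1`, 95% in an ADME assay on the whole organism with Oryza sativa as the target, tested at 0.1 uM; a lower number here means a stronger effect, a higher number a weaker effect of the compound at the concentration tested
compound 2, `CC(=O)c1cccc(NC(=O)N[C@@H](C)c2ccccc2)c1`, 96% in this assay

Compound 1 holds the lowest of the two numbers, and the value of compound 2 lies within the scatter of it, so the two cannot be ordered. Compound 3, `C[C@@H](NC(=O)Nc1ccc(F)cc1)c1ccccc1`, is not yet measured in this assay. It differs from compound 1 as follows: fluoro in place of ethyl on an aromatic carbon. Within the data shown here, no step between two measured compounds is known here, so nothing measured speaks for a change. Both measured values sit close together at a high level; the step of a number 2 percentage points lower from compound 1 to compound 3 (within the scatter) is therefore expected to stay within the scatter. For compound 3 an activity of 93% is estimated, within 80% to 100%.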

Compound 3, a percentage reported as activity, at one concentration (the size of the read-out at that concentration, not a potency): 98%
Compound 3: the middle estimate sits 5 percentage points below what was measured, within the range that was stated.
By their numbers in this assay, from the lowest: compounds 1, 2 and 3 (each within the scatter of the next).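

Fluoro in place of ethyl on an aromatic carbon, para to a large group, gives the first step in one place in this assay, with a number 3 percentage points higher from compound 1 to compound 3 (within the scatter) as its size. At this position, then, exchanging ethyl for fluoro moves the read-out by no more than the scatter, and it remains high with either group. No measurement here bears on this result.

On these data alone, whether an amine, a carboxylic acid or a longer chain at this position would move the read-out beyond the scatter remains open. Also open, as far as these compounds go, is whether a change elsewhere on the shared core would do so.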